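Bromo for Chloro on the Sulfonamide Aryl Ring

The source may hold more compounds than are shown below. What is called first, only, known or untested is meant among the compounds shown, and "the series" means these compounds.

Going by the values given here, compound 3 `COc1ccc(S(=O)(=O)Nc2cc(Br)cc(Cl)c2Cl)cc1N1CCNCC1` gives 3.98 nM in an assay on isolated protein for binding affinity to 5-hydroxytryptamine receptor 6 (Homo sapiens) (a higher number here means a weaker inhibitor, a lower number a stronger inhibitor), which places it second highest of the three numbers known so far. Compound 1 `COc1ccc(S(=O)(=O)Nc2cc(Br)cc(Br)c2)cc1N1CCNCC1` gives 0.501 nM in this assay, and compound 2 `COc1ccc(S(=O)(=O)Nc2c(F)cc(Br)cc2F)cc1N1CCNCC1` gives 158 nM. The step of a 7.9-fold higher number from compound 1 to compound 3 (0.90 log units; beyond the scatter) is modest, while the step of a 40-fold lower number from compound 2 to compound 3 (1.60 log units; beyond the scatter) is large, so compound 3 stands much nearer to compound 1 than to compound 2; the step of a 320-fold higher number from compound 1 to compound 2 (2.50 log units; beyond the scatter) spans the whole range seen.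

Compound 4 `COc1ccc(S(=O)(=O)Nc2cc(Br)cc(Cl)c2Br)cc1N1CCNCC1` has not yet been measured. It differs from compound 3 by bromo in place of chloro on an aromatic carbon of the ring on the sulfonamide nitrogen, ortho to a chloro group and para to a bromo group. Among the compounds with values here, no measured step exchanges a single chloro for a single bromo; the two steps leading to compound 3 each move several halogens at once, so they set an outer bound but do not fix the size of this change. A single halogen exchange of this kind is expected to give a step within or just beyond the scatter, if anything toward a lower number. Compound 4 is therefore expected to give about 2.5 nM in this assay, with a range from 0.8 nM to 8 nM, which is an expected step of a 1.6-fold lower number from compound 3 to compound 4 (0.20 log units; within the scatter).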

Compound 4, inhibition constant: 3.98 nM
Estimate against measurement, compound 4: 1.6-fold (0.20 log units) below, within the range that was stated.
By their numbers in this assay, from the lowest: compound 1; then compounds 3 and 4 (each within the scatter of the next); then compound 2.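

Bromo in place of chloro on this aromatic carbon, ortho to a chloro group and para to a bromo group, is the first exchange of a single halogen in the series, and in this assay it gives no change at the digits printed from compound 3 to compound 4 (within the scatter) and so does not separate the two halogens at this place. The wider gaps are those to the other two ring patterns, with a 7.9-fold higher number from compound 1 to compound 4 (0.90 log units; beyond the scatter) and a 40-fold lower number from compound 2 to compound 4 (1.60 log units; beyond the scatter) matching the gaps already seen for compound 3, so the 2,5-dibromo-3-chlorophenyl group stands where the 5-bromo-2,3-dichlorophenyl group stood relative to both. Nothing available gives a reason why this exchange leaves the number in place.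

The compounds shown do not tell whether the same holds for an exchange of the chloro that compound 4 keeps, since no step isolates that halogen. They also leave open what this assay would give with a group other than a halogen at the place of this bromo, such as an amine, a methoxy or a carboxylic acid.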